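Swapping the Ring on the Core Nitrogen

The source may report more compounds than this note shows. Statements on the series, on what has been measured and on what is new or still open speak of the compounds shown alone.

Of the compounds shown here, three sharing one core have been measured in a functional assay on A549 cells (Homo sapiens) for antiproliferative activity, read by MTT assay, with a stated time of 72 h; a lower number here means a stronger inhibitor, a higher number a weaker inhibitor. Compound 2 `CCNC(=O)c1cc(Oc2ccc(NC(=O)c3cc4cccnc4n(-c4ccccc4)c3=O)cc2)ccn1` gives 160 nM, compound 1 `CNC(=O)c1cc(Oc2ccc(NC(=O)c3cc4cccnc4n(-c4ccc(Cl)cc4)c3=O)cc2)ccn1` gives 370 nM, and compound 3 `CCNC(=O)c1cc(Oc2ccc(NC(=O)c3cc4cccnc4n(-c4ccccc4F)c3=O)cc2)ccn1` gives 490 nM. Compound 3 therefore has the highest number of the three: against compound 1 the gap is within the scatter, while the step of a 3.1-fold higher number from compound 2 to compound 3 (0.49 log units; beyond the scatter) is beyond it.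

Compound 4 `CCNC(=O)c1cc(Oc2ccc(NC(=O)c3cc4cccnc4n(-c4ccc(Cl)cc4)c3=O)cc2)ccn1` is still to be measured. It differs from compound 3 in one place: 4-chlorophenyl in place of 2-fluorophenyl on an aromatic nitrogen. Going by the values given here, the only single-change step in the set, fluoro in place of hydrogen, is the modest rise a 3.1-fold higher number from compound 2 to compound 3 (0.49 log units; beyond the scatter). Compound 1 already carries the 4-chlorophenyl group, together with a different amide, and its number sits between those of compound 2 and compound 3, so this ring is not expected to push the number far either way. The step of a 1.6-fold lower number from compound 3 to compound 4 (0.21 log units; within the scatter) is expected to be small or within the scatter. For compound 4 in this assay the estimate is 300 nM, with a range from 120 nM to 750 nM.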

Compound 4, half-maximal inhibitory concentration: 250 nM
The estimate for compound 4 lay 1.2-fold (0.08 log units) above the measured number, within the range that was stated.
By their numbers in this assay, from the lowest: compounds 2, 4, 1 and 3 (each within the scatter of the next, the first and the last beyond it).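

Exchanging 2-fluorophenyl for 4-chlorophenyl on the aromatic nitrogen gives a 2.0-fold lower number from compound 3 to compound 4 (0.29 log units; within the scatter), so this assay does not separate these two rings. Chloro in place of hydrogen gives a 1.6-fold higher number from compound 2 to compound 4 (0.19 log units; within the scatter), while fluoro in place of hydrogen gave a 3.1-fold higher number from compound 2 to compound 3 (0.49 log units; beyond the scatter), so among these compounds a halogen on this ring moves the number beyond the scatter in compound 3 but not in compound 4. With 4-chlorophenyl held constant, methyl in place of hydrogen on the saturated chain carbon bound to the amide-type nitrogen gives a 1.5-fold lower number from compound 1 to compound 4 (0.17 log units; within the scatter), so this amide change also stays within the scatter.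

No measurement beyond these antiproliferative numbers is available to explain them. The halogen and its place on the ring change together here, which leaves their separate contributions open, as well as how an amine on the phenyl ring or a cyclohexyl group on the core nitrogen would behave.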